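Permeability of a shared core under an aryl swap

The source may hold more compounds than are shown below. What is called first, only, known or untested is meant among the compounds shown, and "the series" means these compounds.

Compound 1 `Fc1ccc(-c2ccc3c(NCCCNCc4ccco4)ccnc3c2)cc1` is the starting point. In an ADME assay for permeability, using PAMPA, with a stated time of 30 min, at pH 7.4 (on this read-out higher numbers stand for higher permeability and lower numbers for lower permeability), compound 1 gives 237 10^-6 cm/s. Two measured neighbours share its core. Compound 2 `COc1cccc(CNCCCNc2ccnc3cc(-c4ccc(F)cc4)ccc23)c1O` gives 237 10^-6 cm/s in this assay, and compound 3 `COc1cccc(CNCCCNc2ccnc3cc(-c4ccc(C(C)(C)C)cc4)ccc23)c1O` gives 237 10^-6 cm/s. Putting 2-hydroxy-3-methoxyphenyl in place of furan-2-yl on a saturated chain carbon bound to an amine nitrogen gives no change at the digits printed from compound 1 to compound 2 (within the scatter). Putting tert-butyl in place of fluoro on an aromatic carbon gives no change at the digits printed from compound 2 to compound 3 (within the scatter). Compound 1 therefore stands level with compound 2 and compound 3 at the digits shown, with no separation among the three.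

Compound 4 `CN(C)c1cccc(Oc2ccc3c(NCCCNCc4ccco4)ccnc3c2)c1` differs from compound 1 in one place: 3-(dimethylamino)phenoxy in place of 4-fluorophenyl on an aromatic carbon. Within the data shown here, of the measured steps, the one from compound 2 to compound 3 also touches the aryl group on the core, and the one from compound 1 to compound 2 alters the chain end; both lie within the scatter. Among the measured compounds shown here, nothing among the measured compounds points to a shift, so for compound 4 the expected step is a 1.0-fold lower number from compound 1 to compound 4 (0.01 log units; within the scatter), none beyond the scatter. The estimate for compound 4 in this assay is 230 10^-6 cm/s, within the range 130 10^-6 cm/s to 260 10^-6 cm/s.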

Compound 4, apparent permeability: 317 10^-6 cm/s
For compound 4 the middle estimate is 1.4-fold (0.14 log units) below the measured one, outside the stated range (above it).
By their numbers in this assay, from the lowest: compounds 1, 2, 3 and 4 (each within the scatter of the next).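

Putting 3-(dimethylamino)phenoxy in place of 4-fluorophenyl on an aromatic carbon of the core of compound 1 gives a 1.3-fold higher number from compound 1 to compound 4 (0.13 log units; within the scatter) in this assay for this swap. Among the earlier compounds, the only change at this position was tert-butyl for fluoro on the aryl group, whereas this step exchanges the whole group: the group that enters holds more heavy atoms than the one that leaves, and the count of hydrogen-bond acceptors goes from 0 to 2, yet the two compounds still read within the scatter of each other. So at this position, a larger group that also carries nitrogen and oxygen gives a value that cannot be told apart from that of compound 1, and no accompanying measurement offers an explanation for this.

The compounds shown leave open whether the oxygen link and the dimethylamino group would each read the same alone, which a plain phenoxy group or a 3-(dimethylamino)phenyl group would separate. They also leave open whether a carboxylic acid or a primary amine on the aryl group at this position would give a step beyond the scatter.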